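Swapping nitro for chloro on an antiproliferative sugar conjugate

A few compounds are considered here, and "the series" means these few. Any claim that something is new, unique, unknown or untested is made for them only; others in the source may bear on it.

Measured so far:
Compound 1, `Nc1nnc(SC[C@H]2O[C@@H](OCc3noc(-c4ccc(Cl)cc4)n3)[C@@H]3OC4(CCCC4)O[C@@H]32)s1`, gives 17000 nM in a functional assay on SW1573 cells (Homo sapiens) for antiproliferative activity, read by sulforhodamine B assay, with a stated time of 48 h; a higher number here means a weaker inhibitor of growth, a lower number a stronger inhibitor of growth.
Compound 2, `COc1cc(-c2nc(CO[C@@H]3O[C@H](CSc4ncn[nH]4)[C@H]4OC5(CCCC5)O[C@@H]34)no2)cc(OC)c1OC`, gives 36000 nM in this assay.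
Compound 3, `O=[N+]([O-])c1ccc(-c2nc(CO[C@@H]3O[C@H](CSc4ncn[nH]4)[C@H]4OC5(CCCC5)O[C@@H]34)no2)cc1`, gives 15000 nM in this assay.

Compound 3 holds the lowest of these three numbers, but it sits close to compound 1, within the scatter, and clearly apart only from compound 2. Among the compounds with values here, the one directly comparable step is a 2.4-fold lower number from compound 2 to compound 3 (0.38 log units; beyond the scatter), a modest shift that came from exchanging one aryl group for another.

Compound 4, `Clc1ccc(-c2nc(CO[C@@H]3O[C@H](CSc4ncn[nH]4)[C@H]4OC5(CCCC5)O[C@@H]34)no2)cc1`, has not been measured in this assay. It differs from compound 3 by chloro in place of nitro on an aromatic carbon. Within the data shown here, no measured pair shows exactly this exchange. Compound 1 carries the same chlorophenyl group but a different sulfur-linked heterocycle, so its value and that of compound 3 sit within the scatter of each other without telling how the chloro itself behaves. With no step of this kind in hand, the expectation is a change of a 1.2-fold higher number from compound 3 to compound 4 (0.08 log units; within the scatter), that is, nothing beyond the scatter in either direction, and compound 4 is estimated at 18000 nM with a range from 7000 nM to 45000 nM.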

Compound 4, concentration for 50% growth inhibition: 10000 nM
Beside the measured number, compound 4's estimate is 1.8-fold (0.26 log units) above it, within the range that was stated.
By their numbers in this assay, from the lowest: compounds 4, 3 and 1 (each within the scatter of the next); then compound 2.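

In this assay, this position on the aromatic ring, para to a large group, accepts chloro in place of nitro with no change that can be told from the scatter: the exchange gives a 1.5-fold lower number from compound 3 to compound 4 (0.18 log units; within the scatter) and so offers no clear gain or loss, even though chloro is a single heavy atom and nitro has three. With the 4-chlorophenyl group held constant, replacing the sulfur-linked 5-amino-1,3,4-thiadiazol-2-yl with 1H-1,2,4-triazol-5-yl gives a 1.7-fold lower number from compound 1 to compound 4 (0.23 log units; within the scatter) and also stays within the scatter, so this pair shows no clear effect of that exchange. Compound 2 remains apart, since the exchange of its 3,4,5-trimethoxyphenyl for 4-chlorophenyl gives a 3.6-fold lower number from compound 2 to compound 4 (0.56 log units; beyond the scatter) and is a modest step beyond the scatter, in the same direction as the earlier step to the 4-nitrophenyl compound.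

Nothing available explains these differences. Still open, as far as these compounds go, is how this position would respond to an amine, a carboxylic acid or a longer chain in place of chloro or nitro, and whether any such group would move the number beyond the scatter.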